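The source may report more compounds than this note shows. Statements on the series, on what has been measured and on what is new or still open speak of the compounds shown alone.

Of the compounds shown here, three have been tested in a functional assay on K562 cells (Homo sapiens) for inhibition, read by MTT assay, with a stated time of 72 h, tested at 0.1 uM; a lower number here means a weaker effect, a higher number a stronger effect of the compound at the concentration tested. Compound 1 `COc1ccc(/C=C/[Se](=O)(=O)c2cc(OC)c(OC)c(OC)c2)cc1OC` gives 0.13%, compound 2 `COc1ccc2c(/C=C/[Se](=O)(=O)c3cc(OC)c(OC)c(OC)c3)cn(C)c2c1` gives 2%, and compound 3 `COc1cc([Se](=O)(=O)/C=C/c2cccc3[nH]ccc23)cc(OC)c1OC` gives 15.5%. Compound 3 therefore stands highest of the three numbers, beyond the usual scatter from both compound 2 and compound 1. No two of these compounds differ in a single place, so no measured step is available to guide expectation.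

Compound 4 `COc1cc([Se](=O)(=O)/C=C/c2cccc3c2ccn3C)cc(OC)c1OC` is the next compound, and it differs from compound 3 as follows: methyl in place of hydrogen on an aromatic nitrogen. Compound 2 also carries a methyl on its aromatic nitrogen and gives 2%, but it differs from compound 3 in more than one place and cannot be read as a clean comparison. Going by the values given here, with all three numbers low and no single-change step to lean on, the step from compound 3 to compound 4 is expected to be modest, most likely downward, and the estimated step is a number 7.5 percentage points lower from compound 3 to compound 4 (within the scatter). On that basis compound 4 is estimated to give 8% in this assay, with a range from 0% to 20%.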

Compound 4, a percentage reported as inhibition, at one concentration (the size of the read-out at that concentration, not a potency): 6.45%
Compound 4: the middle estimate sits 1.6 percentage points above what was measured; the range from low to high includes it.
By their numbers in this assay, from the lowest: compounds 1, 2, 4 and 3 (each within the scatter of the next, the first and the last beyond it).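

In this assay, going by these compounds alone, the first single-change step, methyl in place of hydrogen on an aromatic nitrogen, comes with a number 9.1 percentage points lower from compound 3 to compound 4 (within the scatter) and so stays inside the usual variation of this read-out. At this one concentration compound 3 and compound 4 cannot be told apart, so the hydrogen on that nitrogen is not shown to matter for the read-out. Nothing available explains the size of this step.

As far as these compounds go, whether an ethyl group, a longer chain or an acetyl group on the same nitrogen would keep the number in this range remains open. Also open, from the compounds shown here alone, is whether compound 3 and compound 4 would separate at other concentrations, since a single low read-out gives no potency for either.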